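Working notes: propoxy to hydroxy

A few compounds are considered here, and "the series" means these few. Any claim that something is new, unique, unknown or untested is made for them only; others in the source may bear on it.

Two compounds share the core here, and only one of them has a number. For the measured compounds named here, in a physicochemical assay for lipophilicity, read by HPLC, in phosphate buffer, measured as octanol-water partition, at pH 7.4, tested at 100 uM (a lower number here means a more polar compound, a higher number a more lipophilic compound), compound 2 (`CCCOc1ccc(-c2cccc(CNc3ccc(OCC(=O)O)c(F)c3)c2)c(C)c1`) gives 3.37 and this is the only measured value in the set, so its standing cannot be ranked against anything. The entry for compound 1 (`COc1ccccc1-c1cccc(CNc2ccc(OCC(=O)O)c(F)c2)c1`) reads "not determined" (no result reported) and adds no comparison. Going by the values given here, no step between two measured compounds is available to calibrate a change.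

Compound 3 (`Cc1cc(O)ccc1-c1cccc(CNc2ccc(OCC(=O)O)c(F)c2)c1`) differs from compound 2 in one place (hydrogen in place of propyl on an oxygen on an aromatic ring) with hydrogen in place of propyl on an oxygen on an aromatic ring, which reads as propoxy to hydroxy. The expectation therefore rests on this structural change alone, with compound 2 at 3.37 as the only anchor in this assay. The estimated step (a number 1.37 log units lower from compound 2 to compound 3 (beyond the scatter)) is expected to be downward and well beyond the usual scatter of repeated measurements. For compound 3 the expected value is 2 within an estimated range from 1.5 to 2.6. The width of that range reflects the lack of any measured step.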

Compound 3, distribution coefficient: 1.85
For compound 3 the middle estimate is 0.15 log units above the measured one, and the stated range covers the measured number.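

Working notes: reading the first step

In this assay the series now has its first measured step between compounds that differ in one place: hydrogen in place of propyl on an oxygen on an aromatic ring, read as propoxy to hydroxy, gives a number 1.52 log units lower from compound 2 to compound 3 (beyond the scatter) with the rest of the structure unchanged. This shows that the group carried on this oxygen can shift the distribution coefficient by a large amount, which no earlier comparison could show, and it gives the series a first measured size for a change at this position. Nothing on hand bears on why the step has this size.

This is one step with two end points, so it cannot show how the number changes along the way from hydroxy to propoxy, or whether the change is even and stepwise. An ethoxy group, a longer chain such as butoxy, or a chain ending in an amine or a carboxylic acid on the same oxygen would each test whether the size of this step holds as a trend or belongs to this single pair alone.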